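Para substituent on the aryl group of the shared core

The source may report more compounds than this note shows. Statements on the series, on what has been measured and on what is new or still open speak of the compounds shown alone.

Compound 2 `Cc1nn(C)c2c(O)nc(-c3ccc(C(F)(F)F)cc3)nc12` carries trifluoromethyl on the aryl group of the shared core. In an assay on membranes from brain for binding affinity to adenosine receptor A1 (Rattus norvegicus), read by radioligand binding (on this read-out higher numbers stand for weaker inhibition and lower numbers for stronger inhibition), compound 2 gives 463 nM. Compound 1 `Cc1nn(C)c2c(O)nc(-c3ccc(N)cc3)nc12` carries amino at the same aromatic carbon, and in this assay compound 1 gives 380 nM. Within the data shown here, the only step measured so far, a 1.2-fold higher number from compound 1 to compound 2 (0.09 log units; within the scatter), shows that exchanging amino for trifluoromethyl left the number where it was. Among the two numbers, compound 2 holds the higher one, but the gap to compound 1 lies within the scatter, so no order between them can be stated.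

Compound 3 `Cc1nn(C)c2c(O)nc(-c3ccc(S(=O)(=O)NCCN(C)C)cc3)nc12` is the next member, not yet measured in this assay. The change from compound 2 is (2-(dimethylamino)ethyl)sulfamoyl in place of trifluoromethyl on an aromatic carbon. Among the measured compounds shown here, the single step to hand, from compound 1 to compound 2, bears on the same aromatic carbon and was within the scatter, but it exchanged two small groups, whereas the entering group here is far larger. The expectation for compound 3 is therefore a number close to that of compound 2, with a modest rise allowed: compound 3 is estimated at 600 nM, within 200 nM to 2000 nM, a step of a 1.3-fold higher number from compound 2 to compound 3 (0.11 log units; within the scatter).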

Compound 3, half-maximal inhibitory concentration: 68 nM
Compound 3: the middle estimate sits 8.8-fold (0.95 log units) above what was measured, and the stated range ends above it.
By their numbers in this assay, from the lowest: compound 3; then compounds 1 and 2 (each within the scatter of the next).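

The aromatic carbon on the aryl group of the shared core is not indifferent in this assay: (2-(dimethylamino)ethyl)sulfamoyl in place of trifluoromethyl gives a 6.8-fold lower number from compound 2 to compound 3 (0.83 log units; beyond the scatter) and in place of amino gives a 5.6-fold lower number from compound 1 to compound 3 (0.75 log units; beyond the scatter), both beyond the scatter. Amino and trifluoromethyl, the two groups compared earlier, gave no sign of this, since their step lay within the scatter, so the series now shows that a change at this carbon can move the number. With both of its steps beyond the scatter, compound 3 is the most potent of the three compounds in this series, and the lower number comes with a much larger group, a chain of 9 heavy atoms in place of 4 for trifluoromethyl.

The sulfamoyl link and the dimethylamino end enter together, so the compounds shown cannot tell which part carries the step, and the unsubstituted sulfamoyl group, a shorter or longer chain ending in dimethylamino, or a carboxylic acid on the same chain would bear on this. Nothing at hand gives a reason for the lower number of compound 3.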